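Replacing a Bicyclic Carbon Group with a Methylpyrrole Ring

This account rests on a few compounds, and the source may have more. Where it says the series, first, only, none or still open, it means among the compounds named here.

Compound 1 `CCCn1c(=O)c2nc([C@@H]3CC4C=CC3C4)[nH]c2n(CCC)c1=O` gives 4.3 nM in an assay on cell membranes for binding affinity to adenosine receptor A1 (Cavia porcellus), read by radioligand binding; a higher number here means a weaker inhibitor, a lower number a stronger inhibitor.
Compound 2 `CCCn1c(=O)c2nc([C@@H]3CC4CCC3C4)[nH]c2n(CCC)c1=O` gives 3.8 nM.
Compound 3 `CCCn1c(=O)c2nc(-c3ccco3)[nH]c2n(CCC)c1=O` gives 560 nM.

Among these three numbers compound 1 stands second highest; its nearest neighbour is compound 2, with a 1.1-fold lower number from compound 1 to compound 2 (0.05 log units; within the scatter), and its furthest is compound 3, with a 130-fold higher number from compound 1 to compound 3 (2.11 log units; beyond the scatter). Compound 4 `CCCn1c(=O)c2nc(-c3cccn3C)[nH]c2n(CCC)c1=O` differs from compound 1 in one place: a group of 6 heavy atoms (5 carbon, 1 nitrogen; one five-membered aromatic ring with 1 hetero atom) in place of a group of 7 heavy atoms (7 carbon; 2 five-membered non-aromatic rings of carbon only), on an aromatic carbon. Within the data shown here, two measured steps bear on this change, a 130-fold higher number from compound 1 to compound 3 (2.11 log units; beyond the scatter) and a 150-fold higher number from compound 2 to compound 3 (2.17 log units; beyond the scatter), each swapping the same bicyclic carbon group for a five-membered aromatic ring holding one hetero atom. The methylpyrrole entering here is of that same kind, so a step of similar size toward a higher number is expected: a 120-fold higher number from compound 1 to compound 4 (2.07 log units; beyond the scatter). Compound 4 is therefore estimated at 500 nM, with a likely range from 150 nM to 1800 nM.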

Compound 4, inhibition constant: 140 nM
Beside the measured number, compound 4's estimate is 3.6-fold (0.55 log units) above it, outside the stated range (below it).
By their numbers in this assay, from the lowest: compounds 2 and 1 (each within the scatter of the next); then compound 4; then compound 3.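

Five-membered aromatic rings at this position are not interchangeable: a 4.0-fold lower number from compound 3 to compound 4 (0.60 log units; beyond the scatter) shows that 1-methyl-1H-pyrrol-2-yl gives a stronger inhibitor than furan-2-yl. It still does not recover the strength of the bicyclic carbon groups, with a 33-fold higher number from compound 1 to compound 4 (1.51 log units; beyond the scatter) and a 37-fold higher number from compound 2 to compound 4 (1.57 log units; beyond the scatter) both remaining large steps. Nothing shown explains the difference between the two aromatic rings.

Open is whether the methyl matters, since a pyrrole without it is not among these compounds. A thiophene or phenyl ring here could also show how far the aromatic series extends.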